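A few compounds are considered here, and "the series" means these few. Any claim that something is new, unique, unknown or untested is made for them only; others in the source may bear on it.

Measured compounds:
- Compound 1, `O=C(Nc1ccc(OC(F)(F)F)cc1)c1cc(F)ccc1O`: 850 nM
- Compound 2, `N#Cc1ccc(NC(=O)c2ccc3cccnc3c2O)c(Cl)c1`: 910 nM

Both compounds were tested in a functional assay on HL-60 cells (Homo sapiens) for cytotoxicity, read by luminescence and CellTiter-Glo, with a stated time of 3 days; a higher number here means a weaker inhibitor, a lower number a stronger inhibitor. Compound 1 gives 850 nM and compound 2 gives 910 nM, and the two values lie within the usual scatter of each other, so on these numbers compound 2 is not separated from compound 1 in any direction.

The next compound, compound 3 `N#Cc1ccc(NC(=O)c2ccc3cccnc3c2O)c(C#N)c1`, keeps the whole core of compound 2 and changes one place: cyano in place of chloro on an aromatic carbon. The chloro leaves and a cyano enters on the same aromatic carbon. No pair of measured compounds shows the effect of this kind of change, so there is no shown step to lean on. With the cyano and chloro both being small groups, the change from compound 2 to compound 3 is expected to stay close to the scatter, with no clear direction, so the step of a 1.1-fold higher number from compound 2 to compound 3 (0.04 log units; within the scatter) is estimated to be small. Compound 3 is therefore expected to give about 1000 nM, with a range from 400 nM to 2500 nM.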

Compound 3, half-maximal inhibitory concentration: 890 nM
Compound 3: the middle estimate sits 1.1-fold (0.05 log units) above what was measured; the measured number falls inside the stated range.
By their numbers in this assay, from the lowest: compounds 1, 3 and 2 (each within the scatter of the next).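

Among the compounds shown here, this is the first measured step at this position: in this assay, cyano in place of chloro on an aromatic carbon gives a 1.0-fold lower number from compound 2 to compound 3 (0.01 log units; within the scatter), so the two groups cannot be told apart here. The position, ortho to a large group and meta to a cyano group, therefore accepts this exchange without a readable shift, even though the cyano brings a triple bond and a hydrogen-bond acceptor that the chloro lacks. Nothing measured here explains why the number holds steady across this change.

One exchange cannot show whether this position is insensitive in general or whether these two groups merely happen to match. From the compounds shown here alone, a plain hydrogen, a methoxy group, an amine or a carboxylic acid on this same carbon would test that in this assay, and their effects remain open.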